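This account rests on a few compounds, and the source may have more. Where it says the series, first, only, none or still open, it means among the compounds named here.

Measured in a functional assay on HCT-116 cells (Homo sapiens), read by MTT assay, with a stated time of 72 h (a higher number here means a weaker inhibitor, a lower number a stronger inhibitor), are these compounds:
- Compound 1 `CSc1ncnc2c1c(-c1ccoc1)cn2[C@@H]1O[C@H](CO)[C@@H](O)[C@H]1O`: 100 nM
- Compound 2 `Cc1ncnc2c1c(-c1ccoc1)cn2[C@@H]1O[C@H](CO)[C@@H](O)[C@H]1O`: > 20000 nM (a limit, not a number)
- Compound 3 `Cc1nc(N)c2c(-c3ccoc3)cn([C@@H]3O[C@H](CO)[C@@H](O)[C@H]3O)c2n1`: > 20000 nM (a limit, not a number)

Compound 3 stands at the limit of > 20000 nM in this assay, at which 2 of the 3 values shown sit, and so has no exact number. Compound 4 `C#Cc1cn([C@@H]2O[C@H](CO)[C@@H](O)[C@H]2O)c2nc(C)nc(N)c12` differs from compound 3 in one place. The counted change is ethynyl in place of furan-3-yl on an aromatic carbon and in words it is ethynyl in place of furan-3-yl on an aromatic carbon, two ring bonds from the ring nitrogen.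

Among the compounds with values here, no measured step touches the furan-3-yl group. Within the data shown here, the only measured step is methyl in place of methylsulfanyl, which gave an at least 200-fold higher number from compound 1 to compound 2 (2.30 log units; beyond the scatter) as a large change. It concerns a different group, but it shows that one replacement can shift this assay strongly. A real shift here could show only as a lower number, because compound 3 gives > 20000 nM as a limit. The expected move is an at least 6.6-fold lower number from compound 3 to compound 4 (0.82 log units; beyond the scatter) and it is uncertain, since compound 4 may also stay at the limit. For compound 4 the estimate is 3000 nM with an expected range of 200 nM to 20000 nM in this assay.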

Compound 4, half-maximal inhibitory concentration: > 20000 nM
Compound 4: a limit, no number; the forecaster's own chance of this, stated with the estimate: 45%; middle value at least 6.6-fold (0.82 log units) away from the limit.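

Compound 3 and compound 4 both stand at a limit and not at a number, so no step can be read between them: the limit of > 20000 nM in this assay, at which 3 of the 4 values shown sit.

The compounds shown leave open whether furan-3-yl or ethynyl gives the lower number, and how far either compound lies past the limit.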